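The compounds below may be only part of what the source reports. "The series", "measured", "known", "first", "only" and "open" are said of these compounds alone.

Compound 1 `Cc1ccc(CS/C(=C/c2c(O)cc(O)cc2O)C(=O)c2ccc(Cl)cc2)cc1` gives 50000 nM in a functional assay on DU-145 cells (Homo sapiens) for inhibition, read by trypan blue exclusion, with a stated time of 96 h; a lower number here means a stronger inhibitor of growth, a higher number a weaker inhibitor of growth.
Compound 2 `O=C(/C(=C\c1c(O)cc(O)cc1O)S(=O)(=O)c1ccccc1Br)c1ccc(Cl)cc1` gives 50000 nM in this assay.
Compound 3 `O=C(/C(=C\c1c(O)cc(O)cc1O)Sc1ccccc1Br)c1ccc(Cl)cc1` gives > 100000 nM in this assay, which is a limit of the measurement rather than a number.

Compound 1 stands level with compound 2, the nearest measured neighbour, as the step of no change at the digits printed from compound 1 to compound 2 (within the scatter) shows. Compound 3 sits at the limit (the limit of > 100000 nM in this assay, at which 1 of the 3 values shown sits), so the steps of an at least 2.0-fold higher number from compound 1 to compound 3 (0.30 log units; that floor lies within the scatter) and an at least 2.0-fold higher number from compound 2 to compound 3 (0.30 log units; that floor lies within the scatter) mark only a floor.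

Compound 4 `Cc1ccc(CS/C(=C/c2c[nH]c3ccc(Cl)cc23)C(=O)c2ccc(Cl)cc2)cc1` differs from compound 1 in one place: 5-chloro-1H-indol-3-yl in place of 2,4,6-trihydroxyphenyl on a double-bonded chain carbon bound to a double-bonded chain carbon. Every measured step changes the group on the sulfur or the oxidation of that sulfur, while the group on the double-bonded chain carbon stays the same. For the measured compounds named here, no measured step therefore bears on the change from compound 1 to compound 4, and the data give no direction for it. With nothing to lean on, the expected step of no change at the digits printed from compound 1 to compound 4 (within the scatter) is none beyond the scatter, with a wide range of uncertainty. For compound 4 the estimate in this assay is 50000 nM, between 10000 nM and 200000 nM.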

Compound 4, concentration for 50% growth inhibition: 1000 nM
For compound 4 the middle estimate is 50-fold (1.70 log units) above the measured one; the whole stated range lies above it.
By their numbers in this assay, from the lowest: compound 4; then compounds 1 and 2 (each within the scatter of the next). At a limit, above all of these: compound 3.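

Replacing 2,4,6-trihydroxyphenyl with 5-chloro-1H-indol-3-yl in this assay gives a 50-fold lower number from compound 1 to compound 4 (1.70 log units; beyond the scatter) while the (4-methylbenzyl)sulfanyl group stays unchanged. For the compounds shown here, none of the earlier steps, all of which altered the group on the sulfur or the oxidation of that sulfur, is printed as beyond the scatter, so this is the first position to show a large change in growth inhibition. No measurement shown accounts for the size of this step.

The swap changes the ring and adds a chlorine at once, so an unsubstituted 1H-indol-3-yl or a 5-methoxy-1H-indol-3-yl at this place would be needed to separate those contributions. Going by these compounds, it also remains open whether 5-chloro-1H-indol-3-yl would give a similar change alongside the (2-bromophenyl)sulfonyl group of compound 2.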